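This account rests on a few compounds, and the source may have more. Where it says the series, first, only, none or still open, it means among the compounds named here.

Compound 1 `N#Cc1ccnc(Oc2nn(C3CCC3)c3ncnc(N)c23)c1` gives 2.35 h in an ADME assay on microsomes from liver (Homo sapiens) for metabolic stability, read by LC-MS, using NADPH, with a stated time of 10 min, tested at 10 uM; a higher number here means that the compound lasts longer, a lower number that the compound disappears faster.
Compound 2 `CC(C)(C)n1nc(Oc2cc(Cl)ccn2)c2c(N)ncnc21` gives 1 h in this assay.
Compound 3 `N#Cc1ccnc(Oc2nn([C@H]3C[C@@H](O)C3)c3ncnc(N)c23)c1` reaches > 2.41 h in this assay, which is a limit of the assay rather than a number.

Of the two numbers reported, compound 1 gives the higher one, and the gap down to compound 2 lies beyond the scatter. Going by the values given here, the only single-point step recorded, from compound 1 to compound 3, is an at least 1.0-fold higher number from compound 1 to compound 3 (0.01 log units; that floor lies within the scatter); it ends at the limit of > 2.41 h in this assay, at which 1 of the 3 values shown sits, and concerns a different place in the molecule. Compound 4 `Nc1ncnc2c1c(Oc1cc(C(F)(F)F)ccn1)nn2C1CCC1` has not yet been measured in this assay. It differs from compound 1 as follows: trifluoromethyl in place of cyano on an aromatic carbon. No measured step exchanges the group on that aromatic carbon, so nothing among these compounds shows how this change acts in this assay. The estimate for compound 4 is therefore a step of a 1.2-fold lower number from compound 1 to compound 4 (0.07 log units; within the scatter) in this assay, no larger than the scatter. Compound 4 is expected to give 2 h in this assay, within 1 h to 4 h.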

Compound 4, half-life: 1.02 h
Compound 4: the middle estimate sits 2.0-fold (0.29 log units) above what was measured; the range from low to high includes it.
By their numbers in this assay, from the lowest: compounds 2 and 4 (each within the scatter of the next); then compound 1. At a limit, above all of these: compound 3.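

Going by these compounds alone, for the first time, the compounds show a change on this aromatic carbon, opposite the ring nitrogen, and it is not neutral in this assay: trifluoromethyl in place of cyano gives a 2.3-fold lower number from compound 1 to compound 4 (0.36 log units; beyond the scatter). With the rest of compound 1 kept the same, this position therefore affects how long the compound lasts, and among the two groups seen here, the nitrile gives the longer half-life. Nothing measured here accounts for this step.

Going by these compounds, it remains open whether the shorter half-life is specific to trifluoromethyl or would also appear with other replacements for the nitrile on this carbon, such as a methyl group, a methoxy group or an amine. The compounds also leave open how trifluoromethyl on this carbon would act in combination with the hydroxy group of compound 3.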